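Methyl to Trifluoromethyl on the Core of Compound 2

The source may report more compounds than this note shows. Statements on the series, on what has been measured and on what is new or still open speak of the compounds shown alone.

Compound 1 `CCCCCCCc1nc(O)cc(O)n1` sets the scale: in a functional assay on HEK293 cells for agonist activity at G-protein coupled receptor 84 (Homo sapiens), read by calcium flux (on this read-out lower numbers stand for an effect already at smaller amounts and higher numbers for an effect only at larger amounts of compound), compound 1 gives 12.7 nM. Compound 2 `Cc1cc(O)nc(SCCCCc2ccccc2)n1` gives no number in this assay, only a limit, > 100000 nM. That reading is the limit of > 100000 nM in this assay, at which 1 of the 2 values shown sits. Compound 3 `Oc1cc(C(F)(F)F)nc(SCCCCc2ccccc2)n1` differs from compound 2 in one place: trifluoromethyl in place of methyl on an aromatic carbon. Among the measured compounds shown here, no measured pair differing in a single place exists here to show how large such a change is. A modest gain in this assay is nonetheless expected, an at least 2.5-fold lower number from compound 2 to compound 3 (0.39 log units; beyond the scatter), with a real chance that only a limit returns again. Compound 3 is therefore estimated at 40000 nM, within a range from 3000 nM to 150000 nM.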

Compound 3, half-maximal effective concentration: > 100000 nM
Compound 3: a limit, no number; the forecaster's own chance of this, stated with the estimate: 55%; middle value at least 2.5-fold (0.39 log units) away from the limit.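

Compound 2 and compound 3 each return only a limit, so the step between them cannot be read: the limit of > 100000 nM in this assay, at which 2 of the 3 values shown sit. On these data alone, whether trifluoromethyl in place of methyl changes anything in this assay stays open.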